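Trimming the dichlorobenzyl amide to an anilide

The source may hold more compounds than are shown below. What is called first, only, known or untested is meant among the compounds shown, and "the series" means these compounds.

Compound 1 `N[C@H]1CC[C@H](Nc2c(C(=O)NCc3ccc(Cl)cc3Cl)nc(Br)c3cccnc23)CC1` gives 5000 nM in a functional assay on HEY cells (Homo sapiens) for cytotoxicity, read by MTT assay, with a stated time of 72 h (a lower number here means a stronger inhibitor, a higher number a weaker inhibitor), the lowest of the three numbers. Compound 2 `CN(C)c1ccc(CNC(=O)c2nc(Br)c3cccnc3c2N[C@H]2CC[C@H](N)CC2)cc1` gives 5300 nM, and compound 3 `N[C@H]1CC[C@H](Nc2c(C(=O)NCc3cccc(C(F)(F)F)c3)nc(Br)c3cccnc23)CC1` gives 12000 nM. The step of a 1.1-fold higher number from compound 1 to compound 2 (0.03 log units; within the scatter) lies within the scatter, while a 2.4-fold higher number from compound 1 to compound 3 (0.38 log units; beyond the scatter) is modest.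

Compound 4 `N[C@H]1CC[C@H](Nc2c(C(=O)Nc3ccccc3)nc(Br)c3cccnc23)CC1` differs from compound 1 by phenyl in place of 2,4-dichlorobenzyl on an amide-type nitrogen. The measured steps only swap the aryl group on the saturated carbon; none removes that carbon itself, so they bear on this change only loosely. Those swaps cost at most a modest step, so for compound 4 a step of a 1.8-fold higher number from compound 1 to compound 4 (0.26 log units; within the scatter) toward a somewhat higher number is expected. Compound 4 is therefore estimated at 9000 nM in this assay, within 3000 nM to 30000 nM.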

Compound 4, half-maximal inhibitory concentration: 1000 nM
Estimate against measurement, compound 4: 9.0-fold (0.95 log units) above, outside the stated range (below it).
By their numbers in this assay, from the lowest: compound 4; then compounds 1 and 2 (each within the scatter of the next); then compound 3.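

In this assay the change to phenyl on the amide-type nitrogen gives a 5.0-fold lower number from compound 1 to compound 4 (0.70 log units; beyond the scatter) and a 5.3-fold lower number from compound 2 to compound 4 (0.72 log units; beyond the scatter) and also a 12-fold lower number from compound 3 to compound 4 (1.08 log units; beyond the scatter) in the same direction for all three benzyl amides. This position therefore responds more to the change from benzyl to phenyl than to any of the aryl swaps on the saturated carbon. The compounds shown offer no evidence on why this is so.
Compound 4 also lacks the ring substituents of compounds 1, 2 and 3, so the loss of the saturated carbon is not separated from the loss of those groups. An unsubstituted benzyl or a 2,4-dichlorophenyl on the same nitrogen would separate the two.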